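The source may hold more compounds than are shown below. What is called first, only, known or untested is meant among the compounds shown, and "the series" means these compounds.

Compound 1 `Cc1cccc2sc(NC(=O)CCN3CCN(C(C)(C)C)CC3)nc12` gives 147 nM in an assay on membranes from brain for displacement of a labelled ligand from Sigma non-opioid intracellular receptor 1 (Cavia porcellus), read by scintillation counting, with a stated time of 120 min; on this read-out higher numbers stand for weaker inhibition and lower numbers for stronger inhibition. Compound 2 `CCCCCCN1CCN(CCC(=O)Nc2nc3c(C)cccc3s2)CC1` gives 238 nM in this assay, and compound 3 `Cc1cccc2sc(NC(=O)CCN3CCN(C4CCN(C)CC4)CC3)nc12` gives 6000 nM in this assay, the highest of the three numbers. The change from compound 1 to compound 3 brought a 41-fold higher number from compound 1 to compound 3 (1.61 log units; beyond the scatter), and that from compound 2 to compound 3 brought a 25-fold higher number from compound 2 to compound 3 (1.40 log units; beyond the scatter), whereas between the two alkyl groups there was only a 1.6-fold higher number from compound 1 to compound 2 (0.21 log units; within the scatter). Compound 4 `Cc1ccccc1N1CCN(CCC(=O)Nc2nc3c(C)cccc3s2)CC1` differs from compound 3 in one place: 2-methylphenyl in place of 1-methylpiperidin-4-yl on an amine nitrogen in a ring. Among the measured compounds shown here, no measured compound carries an aromatic group on that ring nitrogen, so the change has no direct match. What bears on it is that both steps leading to compound 3, a 41-fold higher number from compound 1 to compound 3 (1.61 log units; beyond the scatter) and a 25-fold higher number from compound 2 to compound 3 (1.40 log units; beyond the scatter), tie the high number of compound 3 to the 1-methylpiperidin-4-yl group. Taking that group away is therefore expected to lower the number in this assay by a large amount, with the remaining uncertainty resting on how 2-methylphenyl compares with the tert-butyl and hexyl groups of compounds 1 and 2. The step from compound 3 to compound 4 is expected to be a 40-fold lower number from compound 3 to compound 4 (1.60 log units; beyond the scatter). Compound 4 is estimated to give 150 nM in this assay, within a range from 25 nM to 900 nM.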

Compound 4, inhibition constant: 1000 nM
Compound 4: middle estimate off by 6.7-fold (0.82 log units), on the low side; the whole stated range lies below it.
By their numbers in this assay, from the lowest: compounds 1 and 2 (each within the scatter of the next); then compound 4; then compound 3.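

In this assay, 2-methylphenyl on the ring nitrogen recovers only part of what separates 1-methylpiperidin-4-yl from the two alkyl groups, with a 6.0-fold lower number from compound 3 to compound 4 (0.78 log units; beyond the scatter). Compound 4 also stands apart from both alkyl compounds, with a 6.8-fold higher number from compound 1 to compound 4 (0.83 log units; beyond the scatter) and a 4.2-fold higher number from compound 2 to compound 4 (0.62 log units; beyond the scatter), so removing 1-methylpiperidin-4-yl does not by itself bring the number back to that of compounds 1 and 2. The earlier compounds shown here carried no aromatic group at this position, and compound 4 now shows that a six-membered aromatic ring of carbon only gives a number that lies beyond the scatter from those of all three other compounds, placing it in the middle of the series.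

Nothing at hand gives a reason for any of these differences. On these data alone, it remains open whether the number of compound 4 goes with the aromatic ring or with its methyl group, and plain phenyl on the ring nitrogen would address the methyl group, while cyclohexyl would set a carbon-only non-aromatic ring against both 2-methylphenyl and 1-methylpiperidin-4-yl.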